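This account rests on a few compounds, and the source may have more. Where it says the series, first, only, none or still open, it means among the compounds named here.

Compound 1, `COc1cc2c(Oc3ccc(NC(=O)c4nn(-c5ccccc5C(F)(F)F)c(=O)cc4C)cc3F)ccnc2cc1OCCCN1CCC(C)CC1`, gives 60 nM in a functional assay on MKN-45 cells (Homo sapiens) for inhibition, read by MTT assay, with a stated time of 72 h; a higher number here means a weaker inhibitor, a lower number a stronger inhibitor.
Compound 2, `COc1cc2c(Oc3ccc(NC(=O)c4nn(-c5ccccc5C(F)(F)F)c(=O)cc4C)cc3F)ccnc2cc1OCCCN1CCN(C)CC1`, gives 40 nM in this assay.
Compound 3, `COc1cc2c(Oc3ccc(NC(=O)c4nn(-c5ccc(Cl)cc5)c(=O)cc4C)cc3F)ccnc2cc1OCCCN1CCC(C)CC1`, gives 150 nM in this assay.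

All three share one core and differ at two places. Compound 3 differs from compound 1 by 4-chlorophenyl in place of 2-(trifluoromethyl)phenyl on an aromatic nitrogen, and that change produced a 2.5-fold higher number from compound 1 to compound 3 (0.40 log units; beyond the scatter). Compound 2 differs from compound 1 by 4-methylpiperazin-1-yl in place of 4-methylpiperidin-1-yl on a saturated chain carbon, three bonds along the chain from an oxygen on an aromatic ring, which produced a 1.5-fold lower number from compound 1 to compound 2 (0.18 log units; within the scatter). Compound 4, `COc1cc2c(Oc3ccc(NC(=O)c4nn(-c5ccc(Cl)cc5)c(=O)cc4C)cc3F)ccnc2cc1OCCCN1CCN(C)CC1`, has not yet been measured; it differs from compound 3 by 4-methylpiperazin-1-yl in place of 4-methylpiperidin-1-yl on a saturated chain carbon, three bonds along the chain from an oxygen on an aromatic ring. The place of this change is the same word for word as in the pair of compound 1 and compound 2, so it is the same change applied to the core of compound 3. The step is expected to be small, a 1.5-fold lower number from compound 3 to compound 4 (0.18 log units; within the scatter), resting on a 1.5-fold lower number from compound 1 to compound 2 (0.18 log units; within the scatter). Compound 4 is therefore expected to give about 100 nM in this assay, most likely between 50 nM and 250 nM.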

Compound 4, half-maximal inhibitory concentration: 40 nM
Compound 4: the middle estimate sits 2.5-fold (0.40 log units) above what was measured; measured number outside the range, below it.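

Putting 4-methylpiperazin-1-yl in place of 4-methylpiperidin-1-yl gave a 3.8-fold lower number from compound 3 to compound 4 (0.57 log units; beyond the scatter) in this assay, and this step cannot be told apart from the same change on the other core: the same change on two cores in this assay, a 1.5-fold lower number (0.18 log units; within the scatter) from compound 1 to compound 2 and a 3.8-fold lower number (0.57 log units; beyond the scatter) from compound 3 to compound 4, 2.5-fold (0.40 log units) apart, within the scatter of two such steps. Putting 4-chlorophenyl in place of 2-(trifluoromethyl)phenyl gave no change at the digits printed from compound 2 to compound 4 (within the scatter), and this step also cannot be told apart from its earlier counterpart: the same change on two cores in this assay, a 2.5-fold higher number (0.40 log units; beyond the scatter) from compound 1 to compound 3 and no change at the digits printed (within the scatter) from compound 2 to compound 4, 2.5-fold (0.40 log units) apart, within the scatter of two such steps. Both changes may therefore carry from one core to the other, but two pairs per change do not show that either step keeps a fixed size, nor that it would hold on any further core.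

The compounds shown leave open how a longer chain would behave. They also leave open the effect of a dimethylamino group in place of either ring amine.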